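Compound 4: cyano to hydrogen under a cytotoxicity limit

The source may report more compounds than this note shows. Statements on the series, on what has been measured and on what is new or still open speak of the compounds shown alone.

compound 1 `O=C(Nc1cc(-c2ccccn2)n[nH]1)N1CCC(c2cccc(F)c2)CC1`: > 64000 nM
compound 2 `N#Cc1ccc(OC2CCN(C(=O)Nc3cc(-c4ccccn4)n[nH]3)CC2)cc1`: > 63000 nM
compound 3 `O=C(Nc1cc(-c2ccccn2)n[nH]1)N1CCN(c2ccc(F)cc2)CC1`: > 64000 nM

All readings come from an ADME assay on MRC5 cells (Homo sapiens) for cytotoxicity, read by fluorescence and resazurin assay, with a stated time of 3 days (on this read-out higher numbers stand for lower toxicity in this test and lower numbers for higher toxicity in this test), and none of them is a number. Compound 2 sits at the limit of > 63000 nM in this assay, at which 1 of the 3 values shown sits. Compounds 1 and 3 sit at the limit of > 64000 nM in this assay, at which 2 of the 3 values shown sit.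

Compound 4 `O=C(Nc1cc(-c2ccccn2)n[nH]1)N1CCC(Oc2ccccc2)CC1` differs from compound 2 as follows: hydrogen in place of cyano on an aromatic carbon. Among the compounds with values here, the only measured step that touches compound 2 is a step that the two limits leave unreadable from compound 1 to compound 2, and it changes a different group. It gives no size to carry over, so no step beyond the scatter is expected in this assay, in either direction. The expected change is a step that the limit leaves unreadable from compound 2 to compound 4. The estimate for compound 4 is 64000 nM, with an expected range of 32000 nM to 100000 nM.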

Compound 4, half-maximal cytotoxic concentration: > 64000 nM
Compound 4 ended at the assay's limit; the forecaster's own chance of this, stated with the estimate: 85%; the middle value lies on the limit itself.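

In this assay compound 4 gives > 64000 nM, a limit of the assay. The steps from compound 1 and from compound 2 to compound 4 cannot be read. Still open, from the compounds shown here alone, is where each compound's half-maximal cytotoxic concentration lies, and whether hydrogen in place of cyano changes it.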